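Anomeric configuration change within a glycoside cytotoxicity series

The compounds below may be only part of what the source reports. "The series", "measured", "known", "first", "only" and "open" are said of these compounds alone.

Measured compounds:
- compound 1 `CO[C@H]1O[C@H](COc2cccc3c2CCCC3)[C@@H](O)[C@H](O)[C@H]1Oc1ccc(OC2CCCCC2)cc1`: "not determined" (no result reported) in a functional assay on MDA-MB-231 cells (Homo sapiens) for cytotoxicity, read by MTT assay, with a stated time of 48 h; a higher number here means that more compound is needed for the effect, a lower number that less compound is needed
- compound 2 `CO[C@@H]1O[C@H](COc2cccc(C(C)C)c2)[C@@H](O)[C@H](O)[C@H]1Oc1ccc(OC2CCCCC2)cc1`: 40000 nM
- compound 3 `CO[C@H]1O[C@H](COc2ccccc2C(C)C)[C@@H](O)[C@H](O)[C@H]1Oc1ccc(OC2CCCCC2)cc1`: 36000 nM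

Compound 3 gives the lowest of the two numbers in this assay, with compound 2 as its nearest neighbour at a gap that lies within the scatter, so the two cannot be ordered. Compound 1 contributes no number.

Compound 4 `CO[C@@H]1O[C@H](COc2ccccc2C(C)C)[C@@H](O)[C@H](O)[C@H]1Oc1ccc(OC2CCCCC2)cc1` is the next entry. The change from compound 3 is the two compounds have the same atoms and bonds and differ only in configuration as drawn: 1 of 5 stereo elements differ; a stereocentre at a saturated ring carbon is drawn S in compound 3 and R in compound 4. Among the compounds with values here, no step between measured compounds is available for comparison. Given that compound 2 gives 40000 nM and compound 3 gives 36000 nM, the two sitting within the scatter of each other, the step of a 1.1-fold higher number from compound 3 to compound 4 (0.02 log units; within the scatter) is expected to stay within the scatter, with no direction favoured. Compound 4 is therefore estimated at 38000 nM, between 15000 nM and 95000 nM.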

Compound 4, half-maximal effective concentration: 44000 nM
For compound 4 the middle estimate is 1.2-fold (0.06 log units) below the measured one; low and high end bracket the measured number.
By their numbers in this assay, from the lowest: compounds 3, 2 and 4 (each within the scatter of the next).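

In this assay, the stereocentre at a saturated ring carbon, drawn S in compound 3 and R in compound 4, gives a 1.2-fold higher number from compound 3 to compound 4 (0.09 log units; within the scatter), so this centre does not separate the two compounds. This pair isolates configuration alone: the fact that compounds 3 and 4 differ only in the configuration as drawn. The swap of 2-isopropylphenyl for 3-isopropylphenyl gives a 1.1-fold higher number from compound 2 to compound 4 (0.04 log units; within the scatter), so that position of the isopropyl group does not separate compounds 2 and 4 either.

The compounds shown leave open whether configuration at this centre would matter with another group, such as an amine or a carboxylic acid, in place of the isopropyl group. The same question stands for the cyclohexyl group.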